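The compounds below may be only part of what the source reports. "The series", "measured", "known", "first", "only" and "open" are said of these compounds alone.

Series notes. Compound 1 `CCCCNc1nc(NCc2ccco2)c2ccccc2n1` in a functional assay on HCT-116 cells (Homo sapiens) for cytotoxicity, read by MTT assay, with a stated time of 2 days, tested at 10 uM (on this read-out higher numbers stand for more inhibition at the one concentration tested (going by the name of the read-out) and lower numbers for less inhibition), gives 94.8%. Among the measured compounds shown here, compound 2 `CN(C)CCCNc1nc(NCc2ccco2)c2ccccc2n1` in this assay is recorded as "not determined" (no result reported), so compound 2 stands without a number anywhere, and no step from compound 2 can be sized or given a direction. Compound 3 `CCN(CC)CCNc1nc(NCc2ccco2)c2ccccc2n1` is still to be measured in this assay. Against compound 2 the change is diethylamino in place of (dimethylamino)methyl on a saturated chain carbon, two bonds along the chain from a nitrogen on an aromatic ring. With only compound 1 carrying a number, the expectation for compound 3 rests on that single reading. Compound 3 in this assay is estimated at 85%, with the range 60% to 98%.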

Compound 3, a percentage reported as inhibition, at one concentration (the size of the read-out at that concentration, not a potency): 50.3%
Compound 3: the middle estimate sits 34.7 percentage points above what was measured, outside the stated range (below it).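

In this assay, diethylamino in place of ethyl on a saturated chain carbon, two bonds along the chain from a nitrogen on an aromatic ring, goes with a number 44.5 percentage points lower from compound 1 to compound 3 (beyond the scatter). Among the compounds shown here, this is the first readable step, and it shows that the read-out responds to a change at this position. Nothing available bears on the reason for this step.

Steps from compound 2 cannot be read, so the two amine-bearing chains remain uncompared. Also open, going by these compounds, is how a hydroxyl or a morpholine at the chain end would read at this place.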